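A few compounds are considered here, and "the series" means these few. Any claim that something is new, unique, unknown or untested is made for them only; others in the source may bear on it.

Measured compounds in an assay on HEK293 cells for positive allosteric modulation of metabotropic glutamate receptor 2 (Rattus norvegicus), read by thallium flux, with a stated time of 2.5 min; on this read-out lower numbers stand for smaller maximal responses and higher numbers for larger maximal responses:

Compound 1, `Cc1c(OCCCCOc2ccc(F)c(C(=O)O)c2)ccc(C(=O)CC(C)(C)C)c1O`, gives 94.6%.
Compound 2, `COc1cc(C(=O)O)ccc1OCCCCOc1ccc(C(=O)CC(C)(C)C)c(O)c1C`, gives 98.6%.
Compound 3, `CC(=O)c1ccc(OCCCCOc2ccc(F)c(C(=O)O)c2)c(C)c1O`, gives 75.5%.

Compounds 1 and 3 share a core and differ in one place: hydrogen in place of tert-butyl on a saturated chain carbon bound to a carbonyl carbon. This change brought a step of a number 19.1 percentage points lower from compound 1 to compound 3 (beyond the scatter), a modest drop that lies beyond the usual scatter of repeated measurements. Compound 2 carries a different core; the difference between the two cores is not broken down here. In this assay compound 2 stands at the top of the three numbers, yet its gap to compound 1 is within the scatter, so no order between compounds 2 and 1 can be drawn, while its gap to compound 3 lies beyond the scatter.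

Compound 4, `COc1cc(C(=O)O)ccc1OCCCCOc1ccc(C(C)=O)c(O)c1C`, has not yet been measured. It differs from compound 2 in exactly the same way that compound 3 differs from compound 1: hydrogen in place of tert-butyl on a saturated chain carbon bound to a carbonyl carbon. The place of the change is described in the same words for both pairs. Going by the values given here, the only guide to its effect is the one measured step from compound 1 to compound 3, so the same change on the core of compound 2 is expected to bring a similar step of about a number 19.1 percentage points lower from compound 2 to compound 4 (beyond the scatter), because the step of a number 19.1 percentage points lower from compound 1 to compound 3 (beyond the scatter) came from this very change. Since this rests on a single pair and a different core, the expectation is held loosely. Compound 4 is therefore estimated to give 79.5% in this assay, with a plausible range from 66% to 93%.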

Compound 4, largest response reached (reported as percent of maximum), in percent of the reference or control that the assay uses: 86.3%
Compound 4: middle estimate off by 6.8 percentage points, on the low side; the measured number falls inside the stated range.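

In this assay, putting hydrogen in place of tert-butyl on a saturated chain carbon bound to a carbonyl carbon, this time on the core of compound 2, brought a step of a number 12.3 percentage points lower from compound 2 to compound 4 (beyond the scatter), which runs in the same direction as the step on the core of compound 1. Set side by side, the two steps cannot be told apart in size, so in this series the change carried from one core to the other in both direction and magnitude: the same change on two cores in this assay, a number 19.1 percentage points lower (beyond the scatter) from compound 1 to compound 3 and a number 12.3 percentage points lower (beyond the scatter) from compound 2 to compound 4, 6.8 percentage points apart, within the scatter of two such steps This does not show that the change would behave the same way on any further core, since it rests on only two pairs and a single read-out of maximal response, and the numerical gap between the two steps cannot be read as an effect of the core.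

The compounds shown leave open how the response would move with groups other than tert-butyl and hydrogen on that same chain carbon, such as a methyl, an isopropyl or a cyclopropyl group. They also leave open whether an amine at that place would fit the same trend in this assay.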